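Microsomal stability across the distal aryl chain variants

This account rests on a few compounds, and the source may have more. Where it says the series, first, only, none or still open, it means among the compounds named here.

Compound 2 `Cc1nc(C)c([C@H](OC(C)(C)C)C(=O)O)c(N2CCC(C)(C)CC2)c1-c1ccc(OCCc2ccc(F)c(F)c2)cc1` carries a 2-(3,4-difluorophenyl)ethoxy chain on the outer phenyl ring of the shared core. For the measured compounds named here, in an ADME assay on microsomes from liver (Rattus norvegicus) for metabolic stability, read by LC-MS, tested at 0.5 uM (on this read-out higher numbers stand for a longer-lived compound and lower numbers for a shorter-lived compound), compound 2 gives 0.85 h, the only plain number in the set. Compound 1 `Cc1nc(C)c([C@H](OC(C)(C)C)C(=O)O)c(N2CCC(C)(C)CC2)c1-c1ccc(OCCc2ccc(F)cc2F)cc1`, its 2,4-difluorophenyl counterpart, reaches only a limit of the assay, > 2 h, in this assay. The step of an at least 2.3-fold lower number from compound 1 to compound 2 (0.37 log units; beyond the scatter) is therefore at least modest and beyond the scatter, resting on (the limit of > 2 h in this assay, at which 1 of the 2 values shown sits).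

Compound 3 `Cc1nc(C)c([C@H](OC(C)(C)C)C(=O)O)c(N2CCC(C)(C)CC2)c1-c1ccc(CCCc2ccc(F)cc2)cc1` differs from compound 2 by 3-(4-fluorophenyl)propyl in place of 2-(3,4-difluorophenyl)ethoxy on an aromatic carbon. Going by the values given here, the one measured step, from compound 1 to compound 2, swaps fluorine positions on the distal ring while the chain is kept; the change to compound 3 alters the chain itself and drops one fluorine, so that step is only loosely related and gives no direction for the new change. Among the compounds with values here, no other measured pair touches this part of the molecule.

With nothing pointing either way, compound 3 is expected to sit near compound 2, a step of a 1.2-fold higher number from compound 2 to compound 3 (0.07 log units; within the scatter) within the scatter, and its estimated half-life in this assay is 1 h, between 0.4 h and 2.5 h.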

Compound 3, half-life: > 2 h
Compound 3: only a limit was reported (the forecaster's own chance of this, stated with the estimate: 20%); at least 2.0-fold (0.30 log units) between middle value and limit.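

In this assay, replacing 2-(3,4-difluorophenyl)ethoxy with 3-(4-fluorophenyl)propyl on this aromatic carbon gives an at least 2.3-fold higher number from compound 2 to compound 3 (0.37 log units; beyond the scatter). For the compounds shown here, until now, the only readable change at this end of the molecule was a move of fluorine on the distal ring; this step shows that a change to the chain and its ring together also separates a compound from compound 2, which is now the shortest-lived of the three, with steps beyond the scatter to both others. Compound 1 and compound 3 cannot be ordered against each other, and the step between them cannot be read, because both stand at a limit of the assay: the limit of > 2 h in this assay, at which 2 of the 3 values shown sit.

This change replaces the chain oxygen with carbon and also alters the fluorine pattern, so the compounds shown do not separate the contribution of either part; a 3-(3,4-difluorophenyl)propyl chain, which keeps the ring of compound 2 and the chain of compound 3, would bear directly on that. On these data alone, how far compound 1 and compound 3 lie beyond the limit also remains open, so any ranking of the 2,4-difluorophenyl and 4-fluorophenyl variants stays unsettled.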